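This account rests on a few compounds, and the source may have more. Where it says the series, first, only, none or still open, it means among the compounds named here.

Measured so far in a physicochemical assay for solubility; on this read-out higher numbers stand for higher solubility and lower numbers for lower solubility:
compound 1, `CNC(=O)c1cc(C(=O)NC2CC2)cn(CC2CCCCC2)c1=O` — >= 148 ug/mL
compound 2, `CNC(=O)c1cc(C(=O)NC2CC2)cn(Cc2cccc3[nH]ccc23)c1=O` — 78 ug/mL

The value shown for compound 1 is a limit of this assay, not a number. Among the compounds with values here, compound 2 is therefore the only compound with a plain number in this assay, and it is the starting point here. Within the data shown here, the single measured step is an at least 1.8-fold lower number from compound 1 to compound 2 (0.27 log units; that floor lies within the scatter); because compound 1 sits at the limit of >= 148 ug/mL in this assay, at which 1 of the 2 values shown sits, only a floor for that step is known, and the floor itself lies within the usual scatter.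

The step followed here leads to compound 3, `CNC(=O)c1cc(C(=O)NC2CC2)cn(CC2CCCOC2)c1=O`. The change is oxan-3-yl in place of 1H-indol-4-yl on a saturated chain carbon bound to an aromatic nitrogen. This reverses the kind of change seen from compound 1 to compound 2: the 1H-indol-4-yl leaves, and a six-membered non-aromatic ring with one hetero atom enters on the same saturated chain carbon bound to an aromatic nitrogen, as the cyclohexyl of compound 1 does. From compound 1 standing at the limit of >= 148 ug/mL in this assay, at which 1 of the 2 values shown sits, an upward step in this assay is expected, of at least the size seen before, with a fair chance that only a limit is returned.

Compound 3 is expected at 150 ug/mL, with a range of 70 ug/mL to 320 ug/mL. This expectation means an estimated step of a 1.9-fold higher number from compound 2 to compound 3 (0.28 log units; within the scatter).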

Compound 3, solubility: >= 131 ug/mL
Compound 3: a limit, no number; the forecaster's own chance of this, stated with the estimate: 40%; the middle value is on the limit's open side.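

In this assay compound 3 gives >= 131 ug/mL as a limit of the assay, not a number. With oxan-3-yl in place of 1H-indol-4-yl on the saturated chain carbon bound to an aromatic nitrogen, the change gives an at least 1.6-fold higher number from compound 2 to compound 3 (0.22 log units; that floor lies within the scatter) and only a floor is known, because compound 3 sits at a limit: the limit of >= 131 ug/mL in this assay, at which 1 of the 3 values shown sits. Compound 1 and compound 3 both end at limits, so the step between them cannot be read, and the carbon-only cyclohexyl and the oxan-3-yl, with its one ring hetero atom, cannot be told apart on this read-out.

Still open is whether the true step from the 1H-indol-4-yl to either six-membered non-aromatic ring goes beyond the scatter, as the floors shown do not settle it. Also open, as far as these compounds go, is how a group of another kind on the same saturated chain carbon, such as a piperidine with its basic amine nitrogen or a carboxylic acid, would read in this assay and whether it would give a plain number.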